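The source may hold more compounds than are shown below. What is called first, only, known or untested is meant among the compounds shown, and "the series" means these compounds.

Measured so far:
compound 1 `O=C(Nc1ccccc1)c1c(NO)cc(-c2ccc(F)cc2)oc1=O` gives 10300 nM
compound 2 `O=C(Nc1ccc(F)cc1)c1c(NO)cc(-c2ccccc2)oc1=O` gives > 20000 nM

In an ADME assay on Huh-7 cells (Homo sapiens) for cytotoxicity, read by a luciferase reporter and WST assay, with a stated time of 3 days (a lower number here means that less compound is tolerated, a higher number that more compound is tolerated), compound 1 gives 10300 nM. Compound 2 gives > 20000 nM, which is a limit of the assay and not a number. Compound 2 therefore sits at the limit of > 20000 nM in this assay, at which 1 of the 2 values shown sits, and no more can be said of where it stands than that it is tolerated up to that limit. Among the compounds with values here, the two compounds differ in more than one place, so what their values show is only that compound 1 has a number and compound 2 a limit.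

Compound 3 `COc1ccc(NC(=O)c2c(NO)cc(-c3ccccc3)oc2=O)cc1` follows from compound 2 by one change: methoxy in place of fluoro on an aromatic carbon. Within the data shown here, no measured pair shows this change in this assay, so its size is not known from the data. The expected step is a number no higher from compound 2 to compound 3 (the limit leaves the size open), none beyond the usual scatter. Compound 3 is estimated at 20000 nM, within a range from 8000 nM to 50000 nM, with a fair chance that the assay again reports only a limit.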

Compound 3, half-maximal cytotoxic concentration: > 20000 nM
Compound 3: a limit, no number (the forecaster's own chance of this, stated with the estimate: 60%); the middle value lies on the limit itself.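

In this assay compound 3 gives > 20000 nM, which is a limit of the assay and not a number; compound 2 also has only a limit, so no step can be read between the two. The compounds shown leave open what methoxy in place of fluoro does to the tolerated concentration, and how far compound 2 and compound 3 stand past this ceiling: the limit of > 20000 nM in this assay, at which 2 of the 3 values shown sit.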